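Nitrate and furoxan esters of hydroxycinnamates in cells

A few compounds are considered here, and "the series" means these few. Any claim that something is new, unique, unknown or untested is made for them only; others in the source may bear on it.

Compound 1, `O=C(/C=C/c1ccc(OCCCCO[N+](=O)[O-])c(O)c1)OCCCCO[N+](=O)[O-]`, in a functional assay on cells (Homo sapiens) for cytotoxicity, read by resazurin assay, with a stated time of 72 h (a lower number here means a stronger inhibitor, a higher number a weaker inhibitor), reports only a limit, > 50000 nM.
Compound 2, `O=C(/C=C/c1ccc(O)c(O)c1)OCc1c(-c2ccccc2)no[n+]1[O-]`, gives 9170 nM in this assay.
Compound 3, `COc1cc(/C=C/C(=O)OCc2c(-c3ccccc3)no[n+]2[O-])ccc1O`, gives 16500 nM in this assay.

Compound 2 and compound 3 differ by methyl in place of hydrogen on an oxygen on an aromatic ring; this change gave a 1.8-fold higher number from compound 2 to compound 3 (0.26 log units; within the scatter). Compound 4, `COc1cc(/C=C/C(=O)OCCCCO[N+](=O)[O-])ccc1OCCCCO[N+](=O)[O-]`, stands to compound 1 as compound 3 stands to compound 2: methyl in place of hydrogen on an oxygen on an aromatic ring, the same change at the same place. How the core of compound 1 differs from the core of compound 2 is not broken down here. Within the data shown here, compound 1 sits at the limit (the limit of > 50000 nM in this assay, at which 1 of the 3 values shown sits), and the one measured step of this kind left the read-out essentially unchanged; on that basis compound 4 is expected to show a step that the limit leaves unreadable from compound 1 to compound 4. Compound 4 is therefore estimated at 90000 nM, with a range from 40000 nM to 250000 nM, and most likely another limit.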

Compound 4, half-maximal inhibitory concentration: > 50000 nM
Compound 4: no number, only a limit; the forecaster's own chance of this, stated with the estimate: 85%; the middle value does not contradict the limit.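

Compound 1 and compound 4 both give only a limit in this assay, so no step between them can be read: the limit of > 50000 nM in this assay, at which 2 of the 4 values shown sit.

The compounds shown leave open whether methyl in place of hydrogen on that oxygen alters the read-out on the core of compound 1.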